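A Furanyl Group in Place of a Cyanofluorophenyl Group

The source may report more compounds than this note shows. Statements on the series, on what has been measured and on what is new or still open speak of the compounds shown alone.

In an in vitro functional assay on HEK285-7 cells for antagonist activity at prostaglandin D2 receptor 2 (Homo sapiens), read by BRET and beta-arrestin recruitment (a higher number here means a weaker inhibitor, a lower number a stronger inhibitor), compound 1 `O=C(O)Cc1sc(C(c2ccc(F)cc2)c2ccc(F)cc2)nc1-c1ccccc1` gives 240 nM, and compound 3 `N#Cc1cc(-c2nc(C(c3ccc(F)cc3)c3ccc(F)cc3)sc2CC(=O)O)ccc1F` gives 520 nM. Compound 2 `O=C(O)Cc1sc(C(c2ccccc2)c2ccccc2)nc1-c1ccc(C(F)(F)F)cc1` returns only a limit, > 100000 nM, rather than a number. Within the data shown here, of the two numbers, compound 3 stands highest; the one step that reaches it is a 2.2-fold higher number from compound 1 to compound 3 (0.34 log units; beyond the scatter), a modest shift. Compound 4 `O=C(O)Cc1sc(C(c2ccc(F)cc2)c2ccc(F)cc2)nc1-c1ccoc1` differs from compound 3 by furan-3-yl in place of 3-cyano-4-fluorophenyl on an aromatic carbon. Among the measured compounds shown here, only that single measured step bears on an exchange of the aryl group at this position, and it was modest, so a change of comparable size in this assay is expected, with the direction uncertain. For compound 4 the estimate in this assay is 700 nM, with a range from 150 nM to 3500 nM. This estimate corresponds to an expected step of a 1.3-fold higher number from compound 3 to compound 4 (0.13 log units; within the scatter).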

Compound 4, half-maximal inhibitory concentration: 130 nM
Estimate against measurement, compound 4: 5.4-fold (0.73 log units) above; measured number outside the range, below it.
By their numbers in this assay, from the lowest: compounds 4 and 1 (each within the scatter of the next); then compound 3. At a limit, above all of these: compound 2.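

The position on the aromatic carbon next to the ring nitrogen accepts a five-membered aromatic ring with one hetero atom: in this assay, furan-3-yl in place of 3-cyano-4-fluorophenyl gives a 4.0-fold lower number from compound 3 to compound 4 (0.60 log units; beyond the scatter). Set against plain phenyl, furan-3-yl gives a 1.8-fold lower number from compound 1 to compound 4 (0.27 log units; within the scatter), so these two groups cannot be told apart here. Nothing at hand explains why the furan-3-yl does better than the 3-cyano-4-fluorophenyl. The compounds shown leave open whether furan-2-yl or a pyridine ring at this carbon would behave like furan-3-yl.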